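Ring size of the chain amine: compound 2 to compound 4

The source may hold more compounds than are shown below. What is called first, only, known or untested is meant among the compounds shown, and "the series" means these compounds.

Measured in a functional assay on HT-29 cells (Homo sapiens) for cytotoxicity, read by MTT assay, with a stated time of 72 h; a higher number here means a weaker inhibitor, a lower number a stronger inhibitor:
compound 1 `COc1cc2c(Oc3ccc(NC(=O)c4cn(-c5ccccc5Cl)nn4)cc3F)ccnc2cc1OCCCN1CCCC1` gives 150 nM
compound 2 `COc1cc2c(Oc3ccc(NC(=O)c4cn(-c5ccccc5C)nn4)cc3F)ccnc2cc1OCCCN1CCCC1` gives 1200 nM
compound 3 `COc1cc2c(Oc3ccc(NC(=O)c4cn(-c5c(C)cccc5C)nn4)cc3F)ccnc2cc1OCCCN1CCCC1` gives 2240 nM

Compound 2 sits second highest of the three numbers, an 8.0-fold higher number from compound 1 to compound 2 (0.90 log units; beyond the scatter) from compound 1 and a 1.9-fold higher number from compound 2 to compound 3 (0.27 log units; within the scatter) to compound 3. Compound 4 `COc1cc2c(Oc3ccc(NC(=O)c4cn(-c5ccccc5C)nn4)cc3F)ccnc2cc1OCCCN1CCCCC1` differs from compound 2 only by piperidin-1-yl in place of pyrrolidin-1-yl on a saturated chain carbon, three bonds along the chain from an oxygen on an aromatic ring. Among the measured compounds shown here, the measured steps, an 8.0-fold higher number from compound 1 to compound 2 (0.90 log units; beyond the scatter), a 15-fold higher number from compound 1 to compound 3 (1.17 log units; beyond the scatter) and a 1.9-fold higher number from compound 2 to compound 3 (0.27 log units; within the scatter), all alter the aryl group on the triazole; none varies the amine at the end of the propyl chain, so no step in this assay bears directly on the change. The step is therefore expected to be no change at the digits printed from compound 2 to compound 4 (within the scatter), within the scatter in either direction. Compound 4 is estimated at 1200 nM, with a range of 400 nM to 3600 nM.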

Compound 4, half-maximal inhibitory concentration: 1340 nM
The estimate for compound 4 lay 1.1-fold (0.05 log units) below the measured number; measured number inside the range.
By their numbers in this assay, from the lowest: compound 1; then compounds 2, 4 and 3 (each within the scatter of the next).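

In this assay, among the compounds shown here, the amine at the end of the propyl chain varies for the first time: piperidin-1-yl in place of pyrrolidin-1-yl gives a 1.1-fold higher number from compound 2 to compound 4 (0.05 log units; within the scatter). At this position, with the aryl group on the triazole held constant, the change in ring size leaves the number within the scatter, a reading that rests on this single pair. Nothing available explains this result.

As far as these compounds go, whether the same holds with the 2-chlorophenyl group of compound 1 remains open. So does the effect of a morpholin-4-yl or dimethylamino group at the chain end, or of a longer chain.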